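The source may hold more compounds than are shown below. What is called first, only, known or untested is meant among the compounds shown, and "the series" means these compounds.

The series keeps a shared core, seen in compound 1 `c1ccc(-c2ccc3c(NCCCNCc4ccco4)ccnc3c2)cc1` and compound 2 `c1ccc(CCc2ccc3c(NCCCNCc4ccco4)ccnc3c2)cc1`, and varies only the group carried on one aromatic carbon of that core. In an ADME assay for permeability, using PAMPA, with a stated time of 30 min, at pH 7.4 (a lower number here means that the compound crosses the layer more slowly, a higher number that the compound crosses the layer faster), compound 1 gives 237 10^-6 cm/s. Among the compounds with values here, compound 2 gives 23 10^-6 cm/s in this assay, the lower of the two numbers recorded so far, and the single measured step, a 10-fold lower number from compound 1 to compound 2 (1.01 log units; beyond the scatter), is large and well beyond the scatter. Compound 3 `CC(C)(C)c1ccc(-c2ccc3c(NCCCNCc4ccco4)ccnc3c2)cc1` is not yet measured; it differs from compound 2 as follows: 4-(tert-butyl)phenyl in place of phenethyl on an aromatic carbon. Within the data shown here, the one measured step bears on this change in reverse: the phenethyl present in compound 2 leaves, and a 4-(tert-butyl)phenyl enters on the same aromatic carbon, so compound 3 carries a phenyl-type group directly on the core much as compound 1 does. Among the measured compounds shown here, no measured pair shows what the tert-butyl on that outer ring does on its own. The expectation is therefore a step upward from compound 2, of roughly the size already seen, a 6.5-fold higher number from compound 2 to compound 3 (0.81 log units; beyond the scatter). Compound 3 is expected to give about 150 10^-6 cm/s in this assay, in the range 50 10^-6 cm/s to 350 10^-6 cm/s.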

Compound 3, apparent permeability in the ADME assay: 237 10^-6 cm/s
Estimate against measurement, compound 3: 1.6-fold (0.20 log units) below; measured number inside the range.
By their numbers in the ADME assay, from the lowest: compound 2; then compounds 1 and 3 (each within the scatter of the next).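

Compound 3 settles the point the earlier pair could not address, the tert-butyl of the 4-(tert-butyl)phenyl group: in the ADME assay there is no change at the digits printed from compound 1 to compound 3 (within the scatter), so tert-butyl in place of hydrogen makes no readable difference here. The exchange of phenethyl for 4-(tert-butyl)phenyl gives a 10-fold higher number from compound 2 to compound 3 (1.01 log units; beyond the scatter), and among these three compounds the numbers therefore divide by the group on the aromatic carbon, with phenethyl in compound 2 on one side and phenyl and 4-(tert-butyl)phenyl in compounds 1 and 3 on the other. In a physicochemical assay for acid dissociation, compound 2 gives 9.47 and compound 3 gives 9.47, with no change at the digits printed from compound 2 to compound 3 (within the scatter), so the large step in the ADME assay comes with no readable difference in the acid dissociation constant.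

Nothing in hand accounts for the step in the ADME assay. Still open, going by these compounds, is whether the division holds for other groups on this aromatic carbon, such as a benzyl group, and whether the phenyl ring tolerates a substituent of another kind, such as a carboxylic acid or an amine in place of tert-butyl, as it does tert-butyl.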